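The source may report more compounds than this note shows. Statements on the series, on what has been measured and on what is new or still open speak of the compounds shown alone.

Compound 2 `Cc1ccc2c(NCc3ccc(NC(=O)C4CCN(Cc5cc(Cl)ccn5)CC4)cc3)nc(N(C)C)nc2c1` is one of three close analogues tested in a functional assay on SV5A8 cells (Homo sapiens) for cytotoxicity; a lower number here means a stronger inhibitor, a higher number a weaker inhibitor. In this assay compound 2 gives only a limit, > 5400 nM. In this assay compound 1 `Cc1ccc2c(NCc3ccc(NC(=O)C4CCN(Cc5ccccc5)CC4)cc3)nc(N3CCCCCC3)nc2c1` likewise gives only a limit, > 6880 nM. In this assay compound 3 `Cc1ccc2c(NCc3ccc(NC(=O)C4CCN(Cc5ccccc5F)CC4)cc3)nc(N(C)C)nc2c1` again gives only a limit, > 6670 nM. Among the compounds with values here, the one step linking two of these, a step that the two limits leave unreadable from compound 2 to compound 3, is thus unreadable. Compound 4 `COc1ccc(CN2CCC(C(=O)Nc3ccc(CNc4nc(N(C)C)nc5cc(C)ccc45)cc3)CC2)cc1` differs from compound 2 by 4-methoxyphenyl in place of 4-chloropyridin-2-yl on a saturated chain carbon bound to an amine nitrogen in a ring. Within the data shown here, no measured step bears directly on this change, and all three known values are limits, so no step beyond the scatter can be expected in either direction. Compound 4 is therefore expected to sit near 7000 nM, between 3000 nM and 20000 nM, most likely again reported as a limit. The step that the limit leaves unreadable from compound 2 to compound 4 is expected to be small.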

Compound 4, half-maximal inhibitory concentration: > 6180 nM
Compound 4 ended at the assay's limit; the forecaster's own chance of this, stated with the estimate: 80%; the middle value is on the limit's open side.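

Compound 2, compound 3 and compound 4 each give only a limit in this assay, so the steps among them cannot be read. As far as these compounds go, whether changing this aromatic ring alters cytotoxicity at all remains open.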